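Bromo to methoxy on a shared thiazolylidene hydrazide core

The source may hold more compounds than are shown below. What is called first, only, known or untested is meant among the compounds shown, and "the series" means these compounds.

Compound 1: `O=C(CSc1ncccn1)N/N=c1/scc(-c2ccc([N+](=O)[O-])cc2)n1-c1ccccc1` — "not determined" (no result reported)
Compound 2: `O=C(CSc1ncccn1)N/N=c1/scc(-c2ccc(Br)cc2)n1-c1ccccc1` — > 200 ug/mL

Two compounds of the same core have been examined in a functional assay on C6 cells (Rattus norvegicus) for cytotoxicity, read by MTT assay, with a stated time of 24 h; a lower number here means a stronger inhibitor, a higher number a weaker inhibitor. For compound 1 the outcome is recorded only as "not determined" (no result reported), so it gives no number to compare. Compound 2 reaches only the limit of the assay, > 200 ug/mL, and so sits at the limit of > 200 ug/mL in this assay, at which 1 of the 2 values shown sits, rather than at a measured value. Among the compounds with values here, no step between two measured compounds can therefore be described; compound 2 alone marks the ceiling of what the assay reports.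

Compound 3, `COc1ccc(-c2cs/c(=N/NC(=O)CSc3ncccn3)n2-c2ccccc2)cc1`, is the next compound to be tested. It differs from compound 2 by methoxy in place of bromo on an aromatic carbon. Within the data shown here, with compound 2 at a limit, there is no measured step that would tell which way this change moves the read-out. The step from compound 2 to compound 3 is expected to be small, at most within the usual scatter, with an estimated a number no higher from compound 2 to compound 3 (the limit leaves the size open). Compound 3 is thus expected to give about 200 ug/mL, most likely between 100 ug/mL and 400 ug/mL, and it may well again reach only the limit.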

Compound 3, half-maximal inhibitory concentration: 102 ug/mL
Beside the measured number, compound 3's estimate is 2.0-fold (0.29 log units) above it; the measured number falls inside the stated range.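

The change from 4-bromophenyl to 4-methoxyphenyl gives the shared core its first single number in this assay, which shows that a change on this aromatic carbon can bring the read-out inside the range the assay reports. The step can be read only as a floor, an at least 1.9-fold lower number from compound 2 to compound 3 (0.29 log units; that floor lies within the scatter), so the data show its direction but not its full size. Compound 2 stands at a limit and not at a measured number, and the true distance to the methoxy compound stays unknown for that reason: the limit of > 200 ug/mL in this assay, at which 1 of the 3 values shown sits.

Within the data shown here, with only one single number on this core, nothing yet tells whether methoxy is unusual at this position or whether another group in the same place, such as an amine, a carboxylic acid or a longer chain like butoxy, would move the read-out further in either direction. The compounds shown also leave open whether a change elsewhere on the shared core would shift the number as much as this one does, and whether any trend holds across several groups.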